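A few compounds are considered here, and "the series" means these few. Any claim that something is new, unique, unknown or untested is made for them only; others in the source may bear on it.

Of the compounds shown here, three built on a shared core have been tested in a functional assay on HeLa cells (Homo sapiens) for antiproliferative activity, read by MTT assay, with a stated time of 24 h; a higher number here means a weaker inhibitor, a lower number a stronger inhibitor. Compound 1 `Sc1nnc(-c2ccc3c(c2)OCCO3)n1-c1ccccc1` carries only a hydrogen on its sulfur, and in this assay compound 1 gives 51900 nM. Compound 2 `O=[N+]([O-])c1ccc(CSc2nnc(-c3ccc4c(c3)OCCO4)n2-c2ccccc2)cc1` adds a 4-nitrobenzyl group on that sulfur, and in this assay compound 2 gives 36200 nM, the lowest of the two numbers reported, although the step of a 1.4-fold lower number from compound 1 to compound 2 (0.16 log units; within the scatter) stays within the scatter. Compound 3 `Brc1ccccc1CSc1nnc(-c2ccc3c(c2)OCCO3)n1-c1ccccc1` carries a 2-bromobenzyl group instead; in this assay compound 3 reaches only > 100000 nM, which is a limit of the assay and not a number. The step of an at least 1.9-fold higher number from compound 1 to compound 3 (0.28 log units; that floor lies within the scatter) is bounded by the limit of > 100000 nM in this assay, at which 1 of the 3 values shown sits, whereas the step of an at least 2.7-fold higher number from compound 2 to compound 3 (0.44 log units; beyond the scatter) is a floor that lies beyond the scatter.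

Compound 4 `Brc1ccc(CSc2nnc(-c3ccc4c(c3)OCCO4)n2-c2ccccc2)cc1` is not yet measured. It differs from compound 2 in one place: bromo in place of nitro on an aromatic carbon. The closest measured guide is the step of an at least 2.7-fold higher number from compound 2 to compound 3 (0.44 log units; beyond the scatter), but in compound 3 the bromo group sits as 2-bromophenyl rather than 4-bromophenyl, so that step bears only loosely. Taken together with the small step of a 1.4-fold lower number from compound 1 to compound 2 (0.16 log units; within the scatter), a modest rise in the number seems the likeliest outcome. For compound 4 the expected change is a 1.9-fold higher number from compound 2 to compound 4 (0.29 log units; within the scatter), giving an estimate of 70000 nM, with a range from 30000 nM to 200000 nM.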

Compound 4, half-maximal inhibitory concentration: 54600 nM
Compound 4: middle estimate off by 1.3-fold (0.11 log units), on the high side; low and high end bracket the measured number.
By their numbers in this assay, from the lowest: compounds 2, 1 and 4 (each within the scatter of the next). At a limit, above all of these: compound 3.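

In this assay, bromo in place of nitro, on an aromatic carbon para to a large group, gives a 1.5-fold higher number from compound 2 to compound 4 (0.18 log units; within the scatter), so these two groups cannot be told apart at this position, and the 4-bromobenzyl group is likewise not separated from a plain hydrogen on the sulfur, with a 1.1-fold higher number from compound 1 to compound 4 (0.02 log units; within the scatter). The two bromo compounds can be compared only through an at least 1.8-fold lower number from compound 3 to compound 4 (0.26 log units; that floor lies within the scatter), and because that floor lies within the scatter, the data do not settle whether the place of the bromo group on the ring matters. Compound 3 is the only compound held at a limit of the assay, which is not a number: the limit of > 100000 nM in this assay, at which 1 of the 4 values shown sits.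

As far as these compounds go, what remains open is whether any group at this place can move the number beyond the scatter, for instance an amine or a carboxylic acid in place of the bromo or nitro group. From the compounds shown here alone, it also remains open whether a longer chain linking the sulfur to the ring would give a number that stands apart from those of compound 1, compound 2 and compound 4.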